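The compounds below may be only part of what the source reports. "The series", "measured", "known", "first", "only" and "open" are said of these compounds alone.

Of the compounds shown here, three built on one shared core have been tested in an ADME assay on L132 cells (Homo sapiens) for cytotoxicity, read by MTT assay, with a stated time of 72 h; on this read-out lower numbers stand for stronger inhibition and higher numbers for weaker inhibition. Compound 2, `COc1ccc(C2=C(c3cc(OC)c(OC)c(OC)c3)C(=O)C(OC(C)=O)C2)cc1F`, gives < 1 ug/mL, which is a limit of the assay rather than a number. Compound 1, `COc1ccc(C2=C(c3cc(OC)c(OC)c(OC)c3)C(=O)C(OC(C)=O)C2)cc1OC(C)C`, gives > 100 ug/mL, again a limit. Between them lies a single change, (isopropoxy in place of fluoro on an aromatic carbon), and the step is an at least 100-fold higher number from compound 2 to compound 1 (2.00 log units; beyond the scatter). Compound 3, `COc1ccc(C2=C(c3cc(OC)c(OC)c(OC)c3)C(=O)C(O)C2)cc1F`, gives < 1 ug/mL, also a limit. Compound 3 differs from compound 2 in its core by hydrogen in place of acetyl on an oxygen on a saturated carbon, and the step that the two limits leave unreadable from compound 2 to compound 3 cannot be sized, since two of the three values sit at the limit of < 1 ug/mL in this assay, at which 2 of the 3 values shown sit, while one sits at the limit of > 100 ug/mL in this assay, at which 1 of the 3 values shown sits.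

Compound 4, `COc1ccc(C2=C(c3cc(OC)c(OC)c(OC)c3)C(=O)C(O)C2)cc1OC(C)C`, has not yet been tested. It differs from compound 3 by isopropoxy in place of fluoro on an aromatic carbon, the same change as that between compound 2 and compound 1, made at the same place, while the core carries the hydroxy of compound 3 rather than the acetoxy of compound 2. From compound 3 to compound 4 the expected step is an at least 100-fold higher number from compound 3 to compound 4 (2.00 log units; beyond the scatter), resting on the measured step of an at least 100-fold higher number from compound 2 to compound 1 (2.00 log units; beyond the scatter). In this assay compound 4 is expected to show 100 ug/mL, with a likely range from 20 ug/mL to 300 ug/mL, and the result may well again be reported only as a limit.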

Compound 4, half-maximal inhibitory concentration: > 100 ug/mL
Compound 4 was reported as a limit; the forecaster's own chance of this, stated with the estimate: 70%; the middle value sits exactly at the limit.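

In this assay, for the compounds shown here, the change from fluoro to isopropoxy on the aromatic carbon has now been seen on a second core, the one carrying the hydroxy group, with an at least 100-fold higher number from compound 3 to compound 4 (2.00 log units; beyond the scatter). Both steps point the same way and both are beyond the usual scatter, so within these four compounds the change carries over from the acetoxy core to the hydroxy core, and the comparison reads: the same change on two cores in this assay, an at least 100-fold higher number (2.00 log units; beyond the scatter) from compound 2 to compound 1 and an at least 100-fold higher number (2.00 log units; beyond the scatter) from compound 3 to compound 4; the limit leaves it open whether they differ
On these data alone, all four values are limits of the assay rather than numbers, so the true size of the change on either core remains unknown, the two cores cannot be ranked by how much the change matters, and the steps that swap acetyl for hydrogen on the oxygen cannot be read with either fluoro or isopropoxy in place.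

The compounds shown carry only fluoro and isopropoxy at this aromatic carbon, so it stays open how the read-out would respond to a hydroxy group, a methoxy group, an amine or a longer chain such as butoxy there. As far as these compounds go, it also stays open whether the same change would carry over to a core with another group on the saturated carbon, such as an amine or a carboxylic acid in place of the hydroxy or acetoxy group.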